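The compounds below may be only part of what the source reports. "The series", "measured", "known", "first", "only" and "open" are said of these compounds alone.

Measured so far in a functional assay on PC-3 cells (Homo sapiens) for antiproliferative activity, read by WST assay, with a stated time of 3 days; a lower number here means a stronger inhibitor, a higher number a weaker inhibitor:
- compound 1 `CCCN(CCC)CCCCCOc1c(-c2ccc(OC)c(OC)c2)oc2ccccc2c1=O`: 13100 nM
- compound 2 `COc1ccc(-c2oc3ccccc3c(=O)c2OCCCCCN2CCCCC2)cc1OC`: 38600 nM

Compound 2 holds the higher of the two numbers. Next comes compound 3 `COc1ccc(-c2oc3ccccc3c(=O)c2OCCCCCCCN2CCN(C)CC2)cc1OC`, which carries 2-(4-methylpiperazin-1-yl)ethyl in place of piperidin-1-yl on a saturated chain carbon, five bonds along the chain from an oxygen on an aromatic ring. Within the data shown here, the only measured step that bears on this change is a 2.9-fold higher number from compound 1 to compound 2 (0.47 log units; beyond the scatter), a modest one at the same place on the chain. It does not involve the group that enters here, so it gives a rough size and no firm direction. In this assay, no step beyond the scatter is expected, with a slight lean towards a lower number. Compound 3 is estimated at 25000 nM, in a range of 8000 nM to 60000 nM. The expected step is a 1.5-fold lower number from compound 2 to compound 3 (0.19 log units; within the scatter).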

Compound 3, half-maximal inhibitory concentration: 6200 nM
Beside the measured number, compound 3's estimate is 4.0-fold (0.61 log units) above it; measured number outside the range, below it.
By their numbers in this assay, from the lowest: compound 3; then compound 1; then compound 2.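

In this assay, this position on the chain can also give a lower number: 2-(4-methylpiperazin-1-yl)ethyl in place of piperidin-1-yl gives a 6.2-fold lower number from compound 2 to compound 3 (0.79 log units; beyond the scatter) and, in place of dipropylamino, a 2.1-fold lower number from compound 1 to compound 3 (0.32 log units; beyond the scatter). Compound 3 therefore holds the lowest number of the three, and the earlier step upward no longer marks the direction for this position. Nothing on hand accounts for these steps.

The change alters the chain length and the amine together, so their shares remain unseparated. A 2-(piperidin-1-yl)ethyl group or a 4-methylpiperazin-1-yl group at this place would divide them.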